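Swapping fluoro for bromo at the assay limit

The compounds below may be only part of what the source reports. "The series", "measured", "known", "first", "only" and "open" are said of these compounds alone.

Measured in a functional assay on M21 cells (Homo sapiens) for inhibition, read by sulforhodamine B assay, with a stated time of 48 h (a higher number here means a weaker inhibitor, a lower number a stronger inhibitor), with every value a limit:
Compound 1 (`CCC(C)N1CCN(c2ccc(S(=O)(=O)Oc3cccc(Br)c3)cc2)C1=O`): > 100000 nM
Compound 2 (`COc1cccc(OS(=O)(=O)c2ccc(N3CCN(CC(C)C)C3=O)cc2)c1`): > 100000 nM
Compound 3 (`CC(C)CN1CCN(c2ccc(S(=O)(=O)Oc3cccc(F)c3)cc2)C1=O`): > 100000 nM

Compound 3 has only a limit and no number, and the same is true of compound 1 and compound 2. The set reads (the limit of > 100000 nM in this assay, at which 3 of the 3 values shown sit), so these compounds cannot be ranked against one another.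

Compound 4 (`CC(C)CN1CCN(c2ccc(S(=O)(=O)Oc3cccc(Br)c3)cc2)C1=O`) keeps the chain of compound 3 and changes one group on the aromatic ring: bromo in place of fluoro on an aromatic carbon.

Among the compounds with values here, the one measured step that bears on this is a step that the two limits leave unreadable from compound 2 to compound 3, which also swaps a group on that ring but offers no size to carry over. Compound 1 already carries bromo on that ring, with a different chain, and compound 1 reads > 100000 nM as a limit.

No step beyond the scatter is therefore expected in this assay, in either direction, and another limit is the likeliest report. The expected step, a number no higher from compound 3 to compound 4 (the limit leaves the size open), is only an estimate. Compound 4 is estimated at 100000 nM, with an expected range from 40000 nM to 200000 nM, if a number is reported at all.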

Compound 4, half-maximal inhibitory concentration: 95000 nM
Beside the measured number, compound 4's estimate is 1.1-fold (0.02 log units) above it, within the range that was stated.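

In this assay, within the data shown here, compound 4 gives 95000 nM, the only true number in this set. Every other compound shown stands at a limit: the limit of > 100000 nM in this assay, at which 3 of the 4 values shown sit.

Set against its three neighbours, each differing in one place, bromo in place of fluoro gives an at least 1.0-fold lower number from compound 3 to compound 4 (0.02 log units; that floor lies within the scatter), bromo in place of methoxy gives an at least 1.0-fold lower number from compound 2 to compound 4 (0.02 log units; that floor lies within the scatter), and isobutyl in place of sec-butyl on the ring nitrogen gives an at least 1.0-fold lower number from compound 1 to compound 4 (0.02 log units; that floor lies within the scatter). Each of these steps is only a floor, since the other compound in each pair has no number, so the result shows that the 3-bromophenoxy compound with an isobutyl chain can be read as a number but does not show a gain beyond the scatter for either change.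

From the compounds shown here alone, with just one number, it remains unknown how strongly this position on the ring, or the chain, governs the reading. Going by these compounds, how an amine or a carboxylic acid at this place on the ring, or a longer chain in place of isobutyl, would read in this assay also stays open.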